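Methoxy to Nitro: Expected Shift in Cytotoxic Potency

The source may report more compounds than this note shows. Statements on the series, on what has been measured and on what is new or still open speak of the compounds shown alone.

Measured compounds:
compound 1 `O=C(/C=C/c1cccc(OCc2ccccc2)c1)c1ccccc1Br`: 3000 nM
compound 2 `O=C(/C=C/c1cccc(OCc2ccccc2)c1)c1ccc(Br)cc1`: 5700 nM
compound 3 `COc1ccc(C(=O)/C=C/c2cccc(OCc3ccccc3)c2)cc1`: 51300 nM

All three were tested in a functional assay on DU-145 cells (Homo sapiens) for cytotoxicity, read by MTT assay, with a stated time of 68 h; on this read-out higher numbers stand for weaker inhibition and lower numbers for stronger inhibition. Compound 3 gives the highest number of the three, so the weakest inhibition, and its steps to compound 2 and compound 1 both lie beyond the scatter. Compound 4 `O=C(/C=C/c1cccc(OCc2ccccc2)c1)c1ccc([N+](=O)[O-])cc1` differs from compound 3 by nitro in place of methoxy on an aromatic carbon. Within the data shown here, one measured step bears on this position: a 9.0-fold higher number from compound 2 to compound 3 (0.95 log units; beyond the scatter), a modest step, in which methoxy went with a higher number than bromo. Among the measured compounds shown here, no measured compound carries nitro, so the expectation rests on that step alone and is uncertain. A lower number than compound 3 is expected for compound 4, a step of a 3.4-fold lower number from compound 3 to compound 4 (0.53 log units; beyond the scatter). The estimate for compound 4 is 15000 nM, with a range of 4000 nM to 60000 nM.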

Compound 4, half-maximal inhibitory concentration: 52500 nM
Beside the measured number, compound 4's estimate is 3.5-fold (0.54 log units) below it; measured number inside the range.
By their numbers in this assay, from the lowest: compounds 1 and 2 (each within the scatter of the next); then compounds 3 and 4 (each within the scatter of the next).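

In this assay, nitro in place of methoxy at this position makes no readable difference (a 1.0-fold higher number from compound 3 to compound 4 (0.01 log units; within the scatter)), so the weak result of compound 3 is not peculiar to methoxy. Nitro also stands apart from bromo, whichever place bromo holds (a 9.2-fold higher number from compound 2 to compound 4 (0.96 log units; beyond the scatter); an 18-fold higher number from compound 1 to compound 4 (1.24 log units; beyond the scatter)). No measurement shown here accounts for this gap. Still open, from the compounds shown here alone, is whether an amine or a carboxylic acid at this position would group with compound 3 and compound 4 or with the bromo compounds.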